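The source may hold more compounds than are shown below. What is called first, only, known or untested is meant among the compounds shown, and "the series" means these compounds.

Of the compounds shown here, three built on a shared core have been tested in a functional assay on KB cells (Homo sapiens) for cytotoxicity, read by MTT assay, with a stated time of 72 h; a lower number here means a stronger inhibitor, a higher number a weaker inhibitor. Compound 1 `COc1ccc(S(=O)(=O)c2nc3ccccc3nc2N2CCc3ccccc3C2)cc1` reaches only a limit of the assay in this assay, > 50000 nM. Compound 2 `O=S(=O)(c1ccc(Br)cc1)c1nc2ccccc2nc1N1CCc2ccccc2C1` likewise reaches only a limit, > 50000 nM. Within the data shown here, compound 3 `COc1ccc(S(=O)(=O)c2nc3ccccc3nc2N2CCCC(O)C2)cc1` is the one compound with an actual number in this assay, 2120 nM. Compound 2 differs from compound 1 by bromo in place of methoxy on an aromatic carbon; the step that the two limits leave unreadable from compound 1 to compound 2 cannot be read because of the limit of > 50000 nM in this assay, at which 2 of the 3 values shown sit. Compound 3 differs from compound 1 by 3-hydroxypiperidin-1-yl in place of 1,2,3,4-tetrahydroisoquinolin-2-yl on an aromatic carbon, and here the step is clear: an at least 23-fold lower number from compound 1 to compound 3 (1.37 log units; beyond the scatter). Compound 4 `O=S(=O)(c1ccc(Br)cc1)c1nc2ccccc2nc1N1CCCC(O)C1` has not yet been measured. It carries the core of compound 3 and differs from it by bromo in place of methoxy on an aromatic carbon, the same change made from compound 1 to compound 2, at a place described in identical words. The earlier occurrence of this change gave no readable size, so it offers little guidance. The expectation for compound 4 therefore rests mainly on compound 3 with its value 2120 nM. For compound 4 the step is estimated at a 1.2-fold higher number from compound 3 to compound 4 (0.07 log units; within the scatter). Compound 4 is expected to give about 2500 nM, plausibly between 700 nM and 12000 nM.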

Compound 4, half-maximal inhibitory concentration: 3720 nM
The estimate for compound 4 lay 1.5-fold (0.17 log units) below the measured number; low and high end bracket the measured number.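

In this assay the swap of 1,2,3,4-tetrahydroisoquinolin-2-yl for 3-hydroxypiperidin-1-yl, already large on the first core, is large again on the second, with an at least 13-fold lower number from compound 2 to compound 4 (1.12 log units; beyond the scatter) in this pair. The change therefore points the same way on the two cores shown, but two cores make no general rule, and the sizes cannot be set against each other: the same change on two cores in this assay, an at least 23-fold lower number (1.37 log units; beyond the scatter) from compound 1 to compound 3 and an at least 13-fold lower number (1.12 log units; beyond the scatter) from compound 2 to compound 4; the limit leaves it open whether they differ. The other change, bromo in place of methoxy, can be read only once, as a 1.8-fold higher number from compound 3 to compound 4 (0.24 log units; within the scatter), so nothing shows whether it carries from core to core; its step between compound 1 and compound 2 cannot be read because both compounds sit at a limit of the assay: the limit of > 50000 nM in this assay, at which 2 of the 4 values shown sit.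

The compounds shown leave open how this assay would read with an amine or a carboxylic acid in place of the hydroxy on the 3-hydroxypiperidin-1-yl group. They also leave open what a chloro or a nitrile would give in place of the bromo on the 4-bromophenyl group.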